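Swapping a cyclopropyl for a propyl in compound 1

This account rests on a few compounds, and the source may have more. Where it says the series, first, only, none or still open, it means among the compounds named here.

Of the compounds shown here, two sharing one core have been measured in a functional assay on CAL1 cells for inhibition of chemerin-like receptor 1 (Homo sapiens), with a stated time of 45 min; a higher number here means a weaker inhibitor, a lower number a stronger inhibitor. Compound 1, `C[C@H](c1ccc(-c2cc(Cl)ccc2-c2nc(=O)o[nH]2)cc1)N(CC1CC1)c1nc2c(C(=O)O)cccc2o1`, gives 1.3 nM, the lowest of the two numbers. Compound 2, `Cc1ccc(-c2nc(=O)o[nH]2)c(-c2ccc([C@@H](C)N(CC3CC3)c3nc4c(C(=O)O)cccc4o3)cc2)c1`, gives 3.2 nM. Among the compounds with values here, the one measured step, a 2.5-fold higher number from compound 1 to compound 2 (0.39 log units; beyond the scatter), comes from a methyl in place of chloro on an aromatic carbon.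

Compound 3, `CCCCN(c1nc2c(C(=O)O)cccc2o1)[C@H](C)c1ccc(-c2cc(Cl)ccc2-c2nc(=O)o[nH]2)cc1`, is not yet measured. It differs from compound 1 by propyl in place of cyclopropyl on a saturated chain carbon bound to a nitrogen on an aromatic ring; the change sits on a saturated chain carbon bound to a nitrogen on an aromatic ring. Within the data shown here, none of the measured steps touches this part of the molecule, so the measured step from compound 1 to compound 2 offers no direct guide. With no data on this position, the working assumption is a step within the scatter or only a little beyond it, in the weaker direction if anything. Compound 3 is therefore expected to give about 2 nM, within 0.8 nM to 5 nM, an expected 1.5-fold higher number from compound 1 to compound 3 (0.19 log units; within the scatter).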

Compound 3, half-maximal inhibitory concentration: 1.2 nM
Estimate against measurement, compound 3: 1.7-fold (0.22 log units) above; measured number inside the range.
By their numbers in this assay, from the lowest: compounds 3 and 1 (each within the scatter of the next); then compound 2.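

Within the data shown here, compound 1 and compound 3 give the first reading at this position, where the earlier step between compound 1 and compound 2 said nothing. In this assay, a cyclopropyl and a propyl have the same count of 3 heavy atoms, all carbon, yet only the first holds a ring; exchanging one for the other gives a 1.1-fold lower number from compound 1 to compound 3 (0.03 log units; within the scatter) and so leaves the number within the usual scatter. For this pair, then, the ring can be opened, turning cyclopropylmethyl into butyl, with no measurable cost, and nothing at hand explains why the two groups read alike.

Going by these compounds, this single pair cannot show how much room the position has, so it remains open whether a shorter chain such as methyl, a longer chain such as hexyl, or a chain ending in an amine or a hydroxyl would keep the number as well. On these data alone, it also remains open whether butyl would read the same on the core of compound 2, which carries methyl in place of chloro on an aromatic carbon.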